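The source may hold more compounds than are shown below. What is called first, only, known or untested is meant among the compounds shown, and "the series" means these compounds.

Compound 1 `COc1cc2nc(N3CCN(C(C)=O)[C@@H]4CCCC[C@@H]43)nc(N)c2cc1OC`: 44.7 nM
Compound 2 `COc1cc2nc(N3CCN(C(C)=O)[C@H]4CCCC[C@H]43)nc(N)c2cc1OC`: 3020 nM

In a functional assay (strain Wistar) for antagonist activity at Alpha-1A adrenergic receptor (Rattus norvegicus), with stated times of 30 min and 45 min, in the presence of a further agent that is not named here (on this read-out higher numbers stand for weaker binding and lower numbers for tighter binding), compound 1 gives 44.7 nM, the lower of the two numbers recorded so far, and compound 2 gives 3020 nM. Among the measured compounds shown here, the one step measured, a 68-fold higher number from compound 1 to compound 2 (1.83 log units; beyond the scatter), rests on (the fact that compounds 1 and 2 differ only in the configuration as drawn). Compound 3 `COc1cc2nc(N3CCN(C(=O)OCc4ccccc4)[C@@H]4CCCC[C@@H]43)nc(N)c2cc1OC` differs from compound 1 by benzyloxy in place of methyl on a carbonyl carbon. The step from compound 1 to compound 2 changed only the configuration and left the acetyl group untouched, so it does not bear on the change to compound 3 and gives no direction for it. For the measured compounds named here, with no measured step speaking to this change, the number for compound 3 is expected to stay near that of compound 1, and the expected step is a 1.3-fold higher number from compound 1 to compound 3 (0.13 log units; within the scatter), with a wide range on either side. The estimate for compound 3 is 60 nM, expected to fall between 10 nM and 400 nM.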

Compound 3, dissociation constant: 16.2 nM
Compound 3: middle estimate off by 3.7-fold (0.57 log units), on the high side, and the stated range covers the measured number.
By their numbers in this assay, from the lowest: compound 3; then compound 1; then compound 2.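

Until now the carbonyl carbon on the amide-type nitrogen in a ring had carried only methyl, so nothing had shown how this position responds to change. In this assay, acetyl to benzyloxycarbonyl gives a 2.8-fold lower number from compound 1 to compound 3 (0.44 log units; beyond the scatter), so this position takes a far larger group, with a six-membered aromatic ring and one more hydrogen-bond acceptor, and the number still falls, modestly. The information to hand includes nothing that explains this step.

The compounds shown do not separate the contribution of the benzyl ring from that of the added oxygen; a methoxycarbonyl or a benzoyl group at this position would begin to do so. As far as these compounds go, it also remains open whether the mirror image of compound 3 would lose as much ground as compound 2 does against compound 1.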